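A few compounds are considered here, and "the series" means these few. Any claim that something is new, unique, unknown or untested is made for them only; others in the source may bear on it.

Compound 1 `Nc1ccc(C(=O)Nc2nc(-c3ccccc3)nc3c2nnn3Cc2ccccc2)cc1`: 926 nM
Compound 2 `O=C(Nc1nc(-c2ccccc2)nc2c1nnn2Cc1ccccc1)c1ccoc1`: 1640 nM

In an assay on CHO cells for displacement of a labelled ligand from adenosine receptor A3 (Homo sapiens), read by scintillation counting (a lower number here means a stronger inhibitor, a higher number a weaker inhibitor), compound 2 gives the highest of the two numbers, and its nearest neighbour is compound 1, a step of a 1.8-fold higher number from compound 1 to compound 2 (0.25 log units; within the scatter). Compound 3 `O=C(Nc1nc(-c2ccccc2)nc2c1nnn2Cc1ccccc1)C1CCCC1` differs from compound 2 by cyclopentyl in place of furan-3-yl on a carbonyl carbon. Going by the values given here, only that one measured step bears on this change, and it stayed within the scatter; no measured pair exchanges an aromatic ring for a non-aromatic one. Compound 3 is therefore expected to show no step beyond the scatter in this assay, that is a 1.1-fold lower number from compound 2 to compound 3 (0.04 log units; within the scatter). The estimate for compound 3 is 1500 nM, with a range from 500 nM to 4500 nM.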

Compound 3, inhibition constant: 4690 nM
Compound 3: the middle estimate sits 3.1-fold (0.50 log units) below what was measured, and the stated range ends below it.
By their numbers in this assay, from the lowest: compounds 1 and 2 (each within the scatter of the next); then compound 3.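

In this assay, the group on this carbonyl carbon does matter: cyclopentyl in place of furan-3-yl gives a 2.9-fold higher number from compound 2 to compound 3 (0.46 log units; beyond the scatter), and cyclopentyl in place of 4-aminophenyl gives a 5.1-fold higher number from compound 1 to compound 3 (0.70 log units; beyond the scatter). Compound 1 and compound 2, both with aromatic rings, lie within the scatter of each other, so among these three compounds only the non-aromatic ring stands apart. Nothing measured here explains this step. Going by these compounds, whether tetrahydrofuran-3-yl, a non-aromatic ring that keeps the oxygen, would read like furan-3-yl or like cyclopentyl remains open. So does the behaviour of an unsubstituted phenyl or an open butyl chain at this position.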